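Swapping a Nitrile for an Amide: What to Expect

A few compounds are considered here, and "the series" means these few. Any claim that something is new, unique, unknown or untested is made for them only; others in the source may bear on it.

Measured so far in a functional assay on HEK293 cells for agonist activity at Neuronal acetylcholine receptor; alpha4/beta2 (Homo sapiens), read by FLIPR; on this read-out lower numbers stand for an effect already at smaller amounts and higher numbers for an effect only at larger amounts of compound:
compound 1, `COc1cc(N2C[C@@H]3CCNC[C@@H]32)cnc1Br`, gives 1690 nM
compound 2, `N#Cc1cc(N2C[C@@H]3CCNC[C@@H]32)cnc1Br`, gives 109 nM

Compound 2 stands at the lowest number of the two measured; the step of a 16-fold lower number from compound 1 to compound 2 (1.19 log units; beyond the scatter) separates it from compound 1, and that step is well beyond the usual scatter. It came from a cyano group in place of a methoxy group on an aromatic carbon, with the rest of the shared core unchanged.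

Compound 3, `NC(=O)c1cc(N2C[C@@H]3CCNC[C@@H]32)cnc1Br`, has not yet been tested. It differs from compound 2 in one place: carbamoyl in place of cyano on an aromatic carbon. Among the compounds with values here, no measured pair shows this exact exchange, so only the single step from compound 1 to compound 2 bears on it, and only indirectly: it shows that the group at this aromatic carbon matters a great deal. The carbamoyl group keeps the acceptor of the cyano group and adds a donor, but it is a larger group, and on these numbers a modest rise in the value is expected rather than a gain. The step for compound 3 is estimated as a 2.8-fold higher number from compound 2 to compound 3 (0.44 log units; beyond the scatter). Compound 3 is therefore expected to give 300 nM, with a likely range from 100 nM to 1000 nM.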

Compound 3, half-maximal effective concentration: 1490 nM
Compound 3: the middle estimate sits 5.0-fold (0.70 log units) below what was measured; measured number above the stated range.
By their numbers in this assay, from the lowest: compound 2; then compounds 3 and 1 (each within the scatter of the next).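

In this assay, carbamoyl in place of cyano gives a 14-fold higher number from compound 2 to compound 3 (1.14 log units; beyond the scatter) and so gives up nearly all of what the cyano group had gained over methoxy; keeping a hydrogen-bond acceptor and adding a hydrogen-bond donor at this aromatic carbon does not preserve the low number. Carbamoyl in place of methoxy gives a 1.1-fold lower number from compound 1 to compound 3 (0.05 log units; within the scatter), which means these two groups cannot be told apart on this read-out and, among the three groups shown, only the cyano group of compound 2 stands apart from the others. Nothing available here explains why the cyano group differs from the other two groups.

The compounds shown leave open whether the low number belongs to the cyano group alone or could also be reached with a chloro group, a carboxylic acid or an aminomethyl group on this aromatic carbon. They also leave open whether the step between cyano and carbamoyl would keep its size if another group replaced the bromo group.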